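The compounds below may be only part of what the source reports. "The series", "measured", "known", "first", "only" and "open" are said of these compounds alone.

Measured so far:
compound 1 `COc1ccc(S(=O)(=O)N2CC(C(=O)NC3CCN(Cc4ccccc4)CC3)c3ccccc32)c2ccccc12` with 50.1 nM
compound 2 `COc1ccc(S(=O)(=O)N2CC(C(=O)NCCCn3ccnc3)c3ccccc32)c2ccccc12` with 79.4 nM
compound 3 `CN1CCC(N(C)C(=O)C2CN(S(=O)(=O)C3=CC4CCOC4C=C3)c3ccccc32)CC1` with 31.6 nM

All three numbers come from a functional assay on CHO cells for antagonist activity at 5-hydroxytryptamine receptor 6 (Homo sapiens), read by FLIPR; on this read-out lower numbers stand for stronger inhibition and higher numbers for weaker inhibition. Compound 3 gives the lowest of the three; its gap to compound 1 lies within the usual scatter, and only its gap to compound 2 lies beyond it, so compound 3 and compound 1 cannot be separated on these data.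

The next compound, compound 4 `CN1CCC(N(C)C(=O)C2CN(S(=O)(=O)c3ccc(C(F)(F)F)cc3)c3ccccc32)CC1`, keeps the amide and the ring-bound sulfonamide nitrogen of compound 3 and changes only the aryl group on the sulfonyl sulfur: a group of 10 heavy atoms (7 carbon, 3 fluorine; one six-membered aromatic ring of carbon only) in place of a group of 9 heavy atoms (8 carbon, 1 oxygen; one five-membered non-aromatic ring with 1 hetero atom, one six-membered non-aromatic ring of carbon only), on a sulfonyl sulfur. Among the compounds with values here, no pair among the measured compounds isolates a change of this kind, so nothing measured tells how this assay responds to it; the three aryl sulfonyl groups seen so far all sit within a narrow band of numbers.

On that basis a step of about the scatter or less is expected, with no clear direction. Compound 4 is therefore estimated at 50 nM, with a plausible range from 15 nM to 160 nM. The estimate implies a step of a 1.6-fold higher number from compound 3 to compound 4 (0.20 log units; within the scatter), which is expected to stay inside the scatter.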

Compound 4, inhibition constant: 25.1 nM
For compound 4 the middle estimate is 2.0-fold (0.30 log units) above the measured one; measured number inside the range.
By their numbers in this assay, from the lowest: compounds 4, 3, 1 and 2 (each within the scatter of the next, the first and the last beyond it).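

In this assay, the series now has its first step that changes one place, on a sulfonyl sulfur: a 1.3-fold lower number from compound 3 to compound 4 (0.10 log units; within the scatter). The replacement of a non-aromatic group of two rings with 4-(trifluoromethyl)phenyl therefore gives no difference that can be told from the scatter, and in this one pair a group with no hydrogen-bond acceptor matches a group with one. No measurement at hand gives a cause for this result.

As far as these compounds go, it remains open whether this position keeps the same band with an amine or a carboxylic acid on the phenyl ring in place of trifluoromethyl. Also open, from the compounds shown here alone, is whether the same replacement gives a similar step when the amide of compound 1 or compound 2 is present.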